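A few compounds are considered here, and "the series" means these few. Any claim that something is new, unique, unknown or untested is made for them only; others in the source may bear on it.

In a functional assay on PC-3 cells (Homo sapiens) for cytotoxicity, read by WST assay, with a stated time of 72 h (a lower number here means a stronger inhibitor, a higher number a weaker inhibitor), compound 1 `O=C1Nc2c(ccc(F)c2F)C1(c1ccc(O)cc1)c1ccc(F)c(F)c1` gives 19 nM and compound 2 `O=C1Nc2c(ccc(F)c2F)C1(c1ccncc1)c1ccc(O)cc1` gives 110 nM, the higher of the two numbers. Compound 3 `CCCCCC1(c2ccc(O)cc2)C(=O)Nc2c1ccc(F)c2F` carries pentyl in place of pyridin-4-yl on a saturated ring carbon. For the measured compounds named here, the only measured step at this ring carbon is modest, a 5.8-fold higher number from compound 1 to compound 2 (0.76 log units; beyond the scatter), and it is the step that introduces pyridin-4-yl. Pentyl has no ring, so this is a loose guide, but a step of similar size in the opposite direction is expected. The expected change is a 2.8-fold lower number from compound 2 to compound 3 (0.44 log units; beyond the scatter). In this assay compound 3 is estimated at 40 nM, with an expected range of 10 nM to 160 nM.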

Compound 3, half-maximal inhibitory concentration: 1.1 nM
Beside the measured number, compound 3's estimate is 36-fold (1.56 log units) above it, and the stated range ends above it.
By their numbers in this assay, from the lowest: compound 3; then compound 1; then compound 2.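

In this assay, this ring carbon does not need a ring at all: pentyl gives a 100-fold lower number from compound 2 to compound 3 (2.00 log units; beyond the scatter) and a 17-fold lower number from compound 1 to compound 3 (1.24 log units; beyond the scatter) as well. The earlier compounds shown here showed only that pyridin-4-yl fell short of 3,4-difluorophenyl; now both aromatic groups fall well short of a plain chain of carbons.

The compounds shown leave open whether butyl, a longer chain such as heptyl, or a pentyl chain ending in an amine would hold this level. Nothing measured here accounts for the advantage of pentyl.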